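A few compounds are considered here, and "the series" means these few. Any claim that something is new, unique, unknown or untested is made for them only; others in the source may bear on it.

Among the compounds with values here, compound 2, with the structure `CN(C)CCNc1cc2c(cn1)cc(NC(=O)c1ccc(N)cc1)c(=O)n2C`, is one of two compounds so far run in a functional assay on MDA-MB-468 cells (Homo sapiens) for antiproliferative activity, read by MTT assay, with a stated time of 48 h; a higher number here means a weaker inhibitor, a lower number a stronger inhibitor. In this assay compound 2 gives 20400 nM, the highest of the two numbers at hand. Within the data shown here, the only other measured compound, compound 1, has the structure `CCCNc1cc2c(cn1)cc(NC(=O)c1cccc(-c3ccccc3)c1)c(=O)n2C`, and in this assay compound 1 gives 1870 nM; that number is lower than the one for compound 2 by a margin beyond the usual scatter. Compound 1 and compound 2 differ from each other in more than one place, so the two values are stated side by side and nothing more is drawn from their gap.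

The unmeasured compound 3, with the structure `COc1ccc(C(=O)Nc2cc3cnc(NCCN(C)C)cc3n(C)c2=O)cc1`, differs from compound 2 in a single place: methoxy in place of amino on an aromatic carbon. Among the measured compounds shown here, no step of this kind between two measured compounds is on hand, so the effect of the change is not anchored by a precedent. The account therefore rests on the value of compound 2 alone, and the expected step is one of modest size downward, or none beyond the scatter, as a 1.7-fold lower number from compound 2 to compound 3 (0.23 log units; within the scatter) is expected to show. On that basis compound 3 is estimated to give 12000 nM in this assay, within a range from 4000 nM to 40000 nM.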

Compound 3, half-maximal inhibitory concentration: 15700 nM
Beside the measured number, compound 3's estimate is 1.3-fold (0.12 log units) below it; the range from low to high includes it.
By their numbers in this assay, from the lowest: compound 1; then compounds 3 and 2 (each within the scatter of the next).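

Within the data shown here, compound 3 gives the first step that can be read at a single place: on an aromatic carbon of a six-membered aromatic ring of carbon only, para to a large group, methoxy in place of amino comes with a 1.3-fold lower number from compound 2 to compound 3 (0.11 log units; within the scatter) in this assay. This is a step within the scatter, so the numbers do not separate the 4-aminophenyl of compound 2 from the 4-methoxyphenyl of compound 3, even though the exchange goes from 1 hydrogen-bond donor to 0 hydrogen-bond donors and from 1 heavy atom to 2 heavy atoms. No measurement bearing on the two groups is on hand to explain this result.

Amino and methoxy are the only two groups shown at this position, so it remains open whether a fluorine, a carboxylic acid or a longer chain such as ethoxy on the same carbon would also leave the number within the scatter. From the compounds shown here alone, compound 1 differs from compound 2 and compound 3 in more than one place, so what separates its number from theirs also remains open.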